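The compounds below may be only part of what the source reports. "The series", "measured", "known", "first", "only" and "open" are said of these compounds alone.

In a functional assay on SW 1116 cells (Homo sapiens) for antiproliferative activity, read by MTT assay, with a stated time of 24 h (a lower number here means a stronger inhibitor, a higher number a weaker inhibitor), three compounds sharing one core have been measured: compound 1 `O=[N+]([O-])c1ccc(CSc2nnc(-c3ccc4c(c3)OCCO4)n2-c2ccccc2)cc1` gives 13800 nM, compound 2 `Cc1ccc(CSc2nnc(-c3ccc4c(c3)OCCO4)n2-c2ccccc2)cc1` gives 16200 nM and compound 3 `Fc1ccc(CSc2nnc(-c3ccc4c(c3)OCCO4)n2-c2ccccc2)cc1` gives 20800 nM. Compound 3 thus sits within the scatter of both others. The next compound, compound 4 `Fc1cccc(F)c1CSc1nnc(-c2ccc3c(c2)OCCO3)n1-c1ccccc1`, puts 2,6-difluorophenyl in place of 4-fluorophenyl on a saturated chain carbon bound to a sulfur. The nearest evidence is the swaps of a single group on that aromatic ring, namely a 1.5-fold higher number from compound 1 to compound 3 (0.18 log units; within the scatter), a 1.3-fold higher number from compound 2 to compound 3 (0.11 log units; within the scatter) and a 1.2-fold higher number from compound 1 to compound 2 (0.07 log units; within the scatter). None of these compounds carries 2,6-difluorophenyl, so the evidence is indirect, but these small steps suggest no shift beyond the scatter in this assay. The expected result is a 1.2-fold lower number from compound 3 to compound 4 (0.06 log units; within the scatter). Compound 4 is estimated at 18000 nM, with an expected range from 9000 nM to 38000 nM.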

Compound 4, half-maximal inhibitory concentration: 9010 nM
Compound 4: the middle estimate sits 2.0-fold (0.30 log units) above what was measured; low and high end bracket the measured number.
By their numbers in this assay, from the lowest: compounds 4, 1, 2 and 3 (each within the scatter of the next, the first and the last beyond it).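

In this assay, among the compounds shown here, 2,6-difluorophenyl in place of 4-fluorophenyl gives the only step in this set that clears the usual scatter, though a modest one: a 2.3-fold lower number from compound 3 to compound 4 (0.36 log units; beyond the scatter). The other two changes at this position, a 1.8-fold lower number from compound 2 to compound 4 (0.25 log units; within the scatter) and a 1.5-fold lower number from compound 1 to compound 4 (0.19 log units; within the scatter), stay within the scatter, so this ring has so far separated only compound 3 and compound 4. No measurement shown explains the step. Going by these compounds, it remains open how an amine or a carboxylic acid on this ring would read. On these data alone, a longer chain between the sulfur and the ring is equally open.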